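The source may report more compounds than this note shows. Statements on the series, on what has been measured and on what is new or still open speak of the compounds shown alone.

Measured compounds:
- compound 1, `CCC(C)c1ccc(Nc2nc(C)cs2)cc1`: 0%
- compound 2, `CCCCCCc1ccc(Nc2nc(C)cs2)cc1`: "not determined" (no result reported)

The series rests on a shared core carrying a substituted benzene ring, and two members of it are known. Within the data shown here, in an ADME assay on microsomes from liver (Rattus norvegicus) for metabolic stability, with a stated time of 30 min, tested at 1 uM (on this read-out higher numbers stand for a more stable compound and lower numbers for a less stable compound), compound 1 gives 0%; this is the only number in the set, since compound 2 appears without a result. Compound 1 therefore stands alone, at the bottom of the scale this assay can report.

The step to compound 3, `CCC(O)Cc1ccc(Nc2nc(C)cs2)cc1`, is a single change on that ring: 2-hydroxybutyl in place of sec-butyl on an aromatic carbon. Among the measured compounds shown here, no measured pair in the set shares this change, so no step size is known for it. As compound 1 already sits at the floor of this assay, the move to compound 3 cannot go downward beyond the scatter; it is expected either to stay within the scatter or to rise modestly. The estimated step of a number 8 percentage points higher from compound 1 to compound 3 (within the scatter) is small and upward. Compound 3 is expected to give 8% in this assay, with a range from 0% to 30%.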

Compound 3, percent of the compound remaining: 1%
For compound 3 the middle estimate is 7 percentage points above the measured one, within the range that was stated.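

In this assay, 2-hydroxybutyl in place of sec-butyl on an aromatic carbon, para to a group of 7 heavy atoms, gives a number 1 percentage points higher from compound 1 to compound 3 (within the scatter). This is the first reading of any change at this position, and it comes from a starting point at the bottom of the scale, where only a rise could have shown: swapping the four-carbon sec-butyl for a chain with one more heavy atom, an oxygen that brings one hydrogen-bond donor and one acceptor, does not separate the two compounds on this read-out. Nothing in the data accounts for this outcome.

On these data alone, whether any other group on this aromatic carbon, such as an amine, a carboxylic acid or a small fluorinated chain, would bring the number clear of the bottom of the scale stays open. So does whether a change elsewhere on the shared core would do so, since a single step at one position says nothing about the rest of the molecule.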